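This account rests on a few compounds, and the source may have more. Where it says the series, first, only, none or still open, it means among the compounds named here.

Three compounds measured in a physicochemical assay for acid dissociation, share one core and differ in the groups carried on it. Compound 1 `c1ccc(-c2ccc3c(NCCCNCc4ccco4)ccnc3c2)cc1` gives 9.47 in this assay. Compound 2 `COc1ccc(F)cc1CNCCCNc1ccnc2cc(C3CCCCC3)ccc12` gives 9.47, and compound 3 `COc1cccc(CNCCCNc2ccnc3cc(CCC(C)C)ccc23)c1O` gives 9.47. Compound 2 thus stands level with compound 1 and compound 3 at the digits shown; its nearest neighbour is compound 1 and its furthest is compound 3, and both gaps lie within the scatter. Compound 4 `COc1ccc(F)cc1CNCCCNc1ccnc2cc(CC(C)C)ccc12` has not yet been measured in this assay. It differs from compound 2 in one place: isobutyl in place of cyclohexyl on an aromatic carbon The three measured compounds, with varied groups on the core, agree with one another. The step of no change at the digits printed from compound 2 to compound 4 (within the scatter) is expected to be none beyond the scatter. Compound 4 is therefore estimated at 9.47, with a range from 9.2 to 9.75.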

Compound 4, acid dissociation constant: 9.47
Compound 4: middle estimate and measured number agree at the digits printed, and the stated range covers the measured number.
By their numbers in this assay, from the lowest: compounds 1, 2, 3 and 4 (each within the scatter of the next).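

In this assay, going by these compounds alone, isobutyl in place of cyclohexyl on an aromatic carbon gives no change at the digits printed from compound 2 to compound 4 (within the scatter) and so provides the first comparison between compounds that differ in one place. At this position, the loss of the six-membered non-aromatic ring and the change from cyclohexyl to isobutyl leave the read-out within the scatter. No supporting measurement bears on this result. Every group shown at this position contains only carbon and hydrogen. On these data alone, whether an amine or a carboxylic acid there would give a level number remains open.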